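This account rests on a few compounds, and the source may have more. Where it says the series, first, only, none or still open, it means among the compounds named here.

Within the data shown here, in an ADME assay on MT4 cells (Homo sapiens) for cytotoxicity, read by MTT assay (a lower number here means that less compound is tolerated, a higher number that more compound is tolerated), compound 1 (`O=C1c2ccccc2C(=O)N1CCOC(=S)N(C(=O)c1ccc(C(F)(F)F)cc1)c1ccc(Cl)cc1`) gives 10000 nM, and compound 2 (`O=C1c2ccccc2C(=O)N1CCOC(=S)N(C(=O)c1cccc(F)c1F)c1ccc(Cl)cc1`) gives 58000 nM, the higher of the only two numbers available. The next change leads to compound 3 (`O=C1c2ccccc2C(=O)N1CCOC(=S)N(C(=O)c1c(F)cccc1F)c1ccc(Cl)cc1`), which has the same atoms as compound 2, joined differently: 2,6-difluorophenyl in place of 2,3-difluorophenyl on a carbonyl carbon. In words, this puts 2,6-difluorophenyl in place of 2,3-difluorophenyl on a carbonyl carbon. Among the measured compounds shown here, only one measured step bears on this change, a 5.8-fold higher number from compound 1 to compound 2 (0.76 log units; beyond the scatter), which was made on the same carbonyl carbon but exchanged a different group. For the measured compounds named here, no measurement yet shows what rearranging these two fluorines does in this assay. A smaller step than that one is therefore expected, probably none beyond the scatter, with no firm direction. The estimated step is a 1.2-fold lower number from compound 2 to compound 3 (0.06 log units; within the scatter). For compound 3 the expected value is 50000 nM, with an estimated range from 22000 nM to 110000 nM.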

Compound 3, half-maximal cytotoxic concentration: 39000 nM
Compound 3: the middle estimate sits 1.3-fold (0.11 log units) above what was measured; the range from low to high includes it.
By their numbers in this assay, from the lowest: compound 1; then compounds 3 and 2 (each within the scatter of the next).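

In this assay the exchange of 2,3-difluorophenyl for 2,6-difluorophenyl on the carbonyl carbon gives a 1.5-fold lower number from compound 2 to compound 3 (0.17 log units; within the scatter) so the two arrangements of the fluorines cannot be told apart here. Replacing 4-(trifluoromethyl)phenyl with 2,6-difluorophenyl on the same carbonyl carbon gives a 3.9-fold higher number from compound 1 to compound 3 (0.59 log units; beyond the scatter) which shows that a second difluorophenyl group, and not 2,3-difluorophenyl alone, stands beyond the scatter from 4-(trifluoromethyl)phenyl. Nothing measured here accounts for either step.

The compounds shown leave open whether an unsubstituted phenyl or a phenyl with a single fluorine on this carbonyl carbon would read like the difluorophenyl compounds or like compound 1. They also leave open how an amine or a carboxylic acid on that phenyl ring would read in this assay and whether these steps carry over to changes elsewhere in the shared core.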